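Moving the chlorine in compound 2 from 3- to 4-chlorophenyl

A few compounds are considered here, and "the series" means these few. Any claim that something is new, unique, unknown or untested is made for them only; others in the source may bear on it.

In an ADME assay on HepG2 cells (Homo sapiens) for cytotoxicity, read by fluorescence and resazurin assay, with a stated time of 24 h (on this read-out higher numbers stand for lower toxicity in this test and lower numbers for higher toxicity in this test), compound 1 (`O=S1(=O)C=C(Sc2nnc(-c3cccnc3)o2)c2ccccc21`) gives 14000 nM and compound 2 (`O=S1(=O)C=C(Sc2nnc(-c3cccc(Cl)c3)o2)c2ccccc21`) gives 27000 nM so compound 2 sits within the scatter of its only comparator. Compound 3 (`O=S1(=O)C=C(Sc2nnc(-c3ccc(Cl)cc3)o2)c2ccccc21`) is unmeasured and differs from compound 2 as follows: 4-chlorophenyl in place of 3-chlorophenyl on an aromatic carbon (4-chlorophenyl in place of 3-chlorophenyl). Among the measured compounds shown here, the one measured step, a 1.9-fold higher number from compound 1 to compound 2 (0.29 log units; within the scatter) for 3-chlorophenyl in place of pyridin-3-yl, stays within the scatter, and no measured step covers this change. No step beyond the scatter is therefore expected in this assay here. The expected change is a 1.1-fold lower number from compound 2 to compound 3 (0.03 log units; within the scatter) and no more. Compound 3 is estimated at 25000 nM with an expected range of 11000 nM to 55000 nM in this read-out.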

Compound 3, half-maximal cytotoxic concentration: 22000 nM
Beside the measured number, compound 3's estimate is 1.1-fold (0.06 log units) above it; the measured number falls inside the stated range.
By their numbers in this assay, from the lowest: compounds 1, 3 and 2 (each within the scatter of the next).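

In this assay, 4-chlorophenyl in place of 3-chlorophenyl gives a 1.2-fold lower number from compound 2 to compound 3 (0.09 log units; within the scatter), so moving the chlorine around the phenyl ring produces no step beyond the scatter. The change from pyridin-3-yl to 4-chlorophenyl, a 1.6-fold higher number from compound 1 to compound 3 (0.20 log units; within the scatter), also stays within the scatter, so all three groups on this aromatic carbon read alike here. No measured evidence bears on this flat result. The compounds shown leave open whether an amine or a carboxylic acid on the aromatic ring at this place would give a step beyond the scatter.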